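Aryl change in a thiazolidinone series: expected Vero cell cytotoxicity

The source may hold more compounds than are shown below. What is called first, only, known or untested is meant among the compounds shown, and "the series" means these compounds.

Compound 1 `O=C1CSC(c2cccc(F)c2)N1CCN1CCCCC1` was tested in an ADME assay on Vero cells (Chlorocebus sabaeus) for cytotoxicity, read by neutral red uptake, tested at 12.3 ug/mL (on this read-out lower numbers stand for a stronger effect and higher numbers for a weaker effect at the one concentration tested), where compound 1 gave 100%. Compound 2 `COc1cccc(C2SCC(=O)N2CCN2CCCCC2)c1` was tested in the same this assay, and compound 2 gave 100%. On these numbers compound 1 stands level with compound 2: the step of no change at the digits printed from compound 1 to compound 2 (within the scatter) lies within the scatter. Compound 3 `O=C1CSC(c2ccc(O)cc2)N1CCN1CCCCC1` has not yet been measured in this assay. It differs from compound 1 as follows: 4-hydroxyphenyl in place of 3-fluorophenyl on a saturated ring carbon. Among the compounds with values here, the only measured step, the one from compound 1 to compound 2, also changed the substituent on this aromatic ring and brought no change beyond the scatter; on that basis, a step of no size beyond the scatter is expected in this assay, namely a number 2 percentage points lower from compound 1 to compound 3 (within the scatter). For compound 3 the estimated result in this assay is therefore 98%, with an expected range from 85% to 105%.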

Compound 3, a percentage reported as activity, at one concentration (the size of the read-out at that concentration, not a potency): 100%
For compound 3 the middle estimate is 2 percentage points below the measured one; the measured number falls inside the stated range.
By their numbers in this assay, from the lowest: compounds 1, 2 and 3 (each within the scatter of the next).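

In this assay the exchange of 3-fluorophenyl for 4-hydroxyphenyl on the saturated ring carbon gave no change at the digits printed from compound 1 to compound 3 (within the scatter) and thus extends what the earlier pair showed. Compound 1 and compound 2 differ only in a methoxy in place of a fluoro on the aromatic carbon, whereas this change replaces the whole aryl group and brings in 1 hydrogen-bond donor, 1 hydrogen-bond acceptor where the leaving group has 0. At this one concentration, this position therefore tolerates a hydroxyl-bearing phenyl as well, with no effect beyond the scatter. No measurement is offered that would explain this result.

The compounds shown leave open whether an amine or a carboxylic acid on the aromatic ring, or a longer chain in place of that ring, would lower the number. They also leave open how these compounds behave at any other concentration.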